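The source may hold more compounds than are shown below. What is called first, only, known or untested is meant among the compounds shown, and "the series" means these compounds.

Two ureas of the shared core have been run in a functional assay on T47D cells (Homo sapiens) for inhibition, read by sulforhodamine B assay, with a stated time of 48 h, tested at 0.1 uM; on this read-out higher numbers stand for a weaker effect at the one concentration tested and lower numbers for a stronger effect. Compound 1 `O=C(Nc1cccc(-n2cc(-c3ccncc3)c(-c3cc(O)cc(Cl)c3)n2)c1)Nc1ccc(Cl)c(C(F)(F)F)c1` gives 90% in this assay, and compound 2 `COc1cc(Cl)cc(-c2nn(-c3cccc(NC(=O)Nc4cc(C(F)(F)F)cc(C(F)(F)F)c4)c3)cc2-c2ccncc2)c1` gives 96%; the two numbers lie within the usual scatter of each other, so neither compound is set apart from the other on this read-out, and both sit at the weak end of the scale at the single concentration used. Compound 3 `COc1cc(Cl)cc(-c2nn(-c3cccc(NC(=O)Nc4cccc(C(F)(F)F)c4)c3)cc2-c2ccncc2)c1` has not yet been run in this assay. It differs from compound 2 on an aromatic carbon of a six-membered aromatic ring of carbon only: hydrogen in place of trifluoromethyl on an aromatic carbon. Within the data shown here, no pair of measured compounds differs in one place, so there is no measured step to set this change against. The working expectation is that the step of a number 1 percentage points lower from compound 2 to compound 3 (within the scatter) stays within the scatter, given how little room the read-out of compound 2 at 96% leaves. Compound 3 is therefore estimated at 95%, with a range from 85% to 102%.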

Compound 3, a percentage reported as activity, at one concentration (the size of the read-out at that concentration, not a potency): 94%
Estimate against measurement, compound 3: 1 percentage points above, and the stated range covers the measured number.
By their numbers in this assay, from the lowest: compounds 1, 3 and 2 (each within the scatter of the next).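

Among these compounds, the step of a number 2 percentage points lower from compound 2 to compound 3 (within the scatter) is the first measured one at this position in this assay, and it shows that hydrogen in place of trifluoromethyl on this aromatic carbon, meta to a trifluoromethyl group, gives no difference that the read-out can separate. Among the compounds shown here, both compounds of the pair sit at the weak end of the scale, so the step shows only that this change does not bring out an effect at the one concentration tested; it does not show that the group is without consequence under other conditions. No supporting data bear on this result.

As far as these compounds go, whether an amine or a carboxylic acid on this aromatic carbon would move the read-out away from the weak end remains open. From the compounds shown here alone, it also remains open whether compound 2 and compound 3 would separate at a higher concentration.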